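Aryl ether aminoquinoline series: alkyl ether variation

The source may hold more compounds than are shown below. What is called first, only, known or untested is meant among the compounds shown, and "the series" means these compounds.

Measured so far:
- compound 1, `CC#CCCOc1cccc2ccc(N)nc12`: > 2000 nM
- compound 2, `CC(CC(C)(C)C)Oc1cccc2ccc(N(C)C)nc12`: > 2000 nM

In an assay on cells with melanin-concentrating hormone receptor 1 (Homo sapiens) as the target, read by radioligand binding (a higher number here means a weaker inhibitor, a lower number a stronger inhibitor), compound 1 gives > 2000 nM, a limit of the assay rather than a number. In this assay compound 2 likewise gives > 2000 nM, also a limit. Both values sit at the limit of > 2000 nM in this assay, at which 2 of the 2 values shown sit, so compound 1 has no resolved position in this assay.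

Compound 3, `CCCC(C)Oc1cccc2ccc(N)nc12`, is not yet measured. It differs from compound 1 in one place: 1-methylbutyl in place of pent-3-yn-1-yl on an oxygen on an aromatic ring.

For the measured compounds named here, no step between measured compounds exists to size this change. Compound 2, an ether with a branched alkyl group, also gives only a limit, so no change beyond the scatter is expected for a step that the limit leaves unreadable from compound 1 to compound 3. Compound 3 is expected to give 3000 nM, within 800 nM to 15000 nM, most likely again as a limit.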

Compound 3, half-maximal inhibitory concentration: 105 nM
Beside the measured number, compound 3's estimate is 29-fold (1.46 log units) above it, outside the stated range (below it).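

On an oxygen on an aromatic ring, 1-methylbutyl in place of pent-3-yn-1-yl brings a resolved value in this assay, with an at least 19-fold lower number from compound 1 to compound 3 (1.27 log units; beyond the scatter). Both groups count 5 heavy atoms, so this position responds to more than chain size alone. The true size of the step remains unknown because compound 1 gives a limit rather than a number: the limit of > 2000 nM in this assay, at which 2 of the 3 values shown sit.

Whether the branch or the loss of the triple bond accounts for the step stays open; a straight pentyl chain on the same oxygen would separate the two. As far as these compounds go, how a longer chain or an amine would read here is also open.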